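This account rests on a few compounds, and the source may have more. Where it says the series, first, only, none or still open, it means among the compounds named here.

Of the compounds shown here, three sharing one core have been measured in a functional assay on HepG2 cells (Homo sapiens) for antiproliferative activity, read by MTT assay, with a stated time of 48 h; on this read-out lower numbers stand for stronger inhibition and higher numbers for weaker inhibition. Compound 1 `CC(=O)N1N=C(c2ccc3ccccc3c2)OC1c1ccccc1Br` gives 3.98 ug/mL, compound 2 `CC(=O)N1N=C(c2ccc3ccccc3c2)OC1c1ccccc1F` gives 3.36 ug/mL, and compound 3 `CC(=O)N1N=C(c2ccc3ccccc3c2)OC1c1ccccn1` gives 5.26 ug/mL. Compound 3 therefore sits within the usual scatter of the other two, and these numbers do not separate the three.

The next compound, compound 4 `CC(=O)N1N=C(c2ccc3ccccc3c2)OC1c1ccncc1`, keeps the core and changes one group: pyridin-4-yl in place of pyridin-2-yl on a saturated ring carbon. Among the compounds with values here, no measured pair tests this exact swap. The closest evidence comes from the two steps that introduced pyridin-2-yl at the same place, a 1.3-fold higher number from compound 1 to compound 3 (0.12 log units; within the scatter) and a 1.6-fold higher number from compound 2 to compound 3 (0.19 log units; within the scatter). The halogen swap elsewhere on that ring was just as small, at a 1.2-fold lower number from compound 1 to compound 2 (0.07 log units; within the scatter). Since every change so far has stayed small, no step beyond the scatter is expected in this assay, and the data favour no direction. The estimated step is a 1.1-fold lower number from compound 3 to compound 4 (0.06 log units; within the scatter). For compound 4 the expected value is 4.6 ug/mL, with an estimated range of 2.6 ug/mL to 8 ug/mL.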

Compound 4, half-maximal inhibitory concentration: 2.17 ug/mL
Compound 4: middle estimate off by 2.1-fold (0.33 log units), on the high side; measured number below the stated range.
By their numbers in this assay, from the lowest: compounds 4, 2, 1 and 3 (each within the scatter of the next, the first and the last beyond it).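

On this saturated ring carbon, a swap that keeps the same atoms and only joins them differently, pyridin-4-yl in place of pyridin-2-yl, gives a 2.4-fold lower number from compound 3 to compound 4 (0.38 log units; beyond the scatter) in this assay; this modest step is the only one among these compounds that lies beyond the scatter, so how this ring is joined to the core can count here even when its atoms do not change. Set against the halogenated rings, the picture is different: a 1.5-fold lower number from compound 2 to compound 4 (0.19 log units; within the scatter) and a 1.8-fold lower number from compound 1 to compound 4 (0.26 log units; within the scatter) both stay within the scatter, so compound 4 separates only from compound 3. No accompanying measurement explains the step.

From the compounds shown here alone, how pyridin-3-yl would behave on the same carbon stays open. So does whether an amine or a carboxylic acid on this ring would shift the number in either direction.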